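This account rests on a few compounds, and the source may have more. Where it says the series, first, only, none or still open, it means among the compounds named here.

Measured so far:
- compound 1, `CCCCCCCCCCc1ccc(-c2noc(CCCCN)n2)cc1`: 55%
- compound 2, `CCCCCCCCCCc1ccc(-c2noc(CCCN(C)C)n2)cc1`: 8%
- compound 3, `CCCCCCCCCCc1ccc(-c2noc(CC3CCNC3)n2)cc1`: 44%

All three share one core and differ only in the group hanging off it. In an assay on HeLa cells for inhibition of sphingosine-1-phosphate transporter SPNS2 (Mus musculus), read by LC-MS, tested at 2 uM (on this read-out lower numbers stand for less inhibition and higher numbers for more inhibition at the one concentration tested (going by the name of the read-out)), compound 2 gives 8%, the lowest of the three numbers: compound 1 gives 55%, a step of a number 47 percentage points lower from compound 1 to compound 2 (beyond the scatter), and compound 3 gives 44%, a step of a number 36 percentage points higher from compound 2 to compound 3 (beyond the scatter), both beyond the scatter.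

Compound 4, `CCCCCCCCCCc1ccc(-c2noc([C@@H]3CCCN3)n2)cc1`, has not been measured. It differs from compound 2 in one place: pyrrolidin-2-yl in place of 3-(dimethylamino)propyl on an aromatic carbon. The group that leaves carries no hydrogen-bond donor; the group that enters is a five-membered ring with one hydrogen-bond donor.

Within the data shown here, two measured steps bear on this. From compound 2 to compound 3, a 3-(dimethylamino)propyl chain was likewise exchanged for a pyrrolidinyl ring, and inhibition rose by a number 36 percentage points higher from compound 2 to compound 3 (beyond the scatter). From compound 1 to compound 2, moving from a group with a hydrogen-bond donor to one without gave a number 47 percentage points lower from compound 1 to compound 2 (beyond the scatter). Both point the same way, so a large rise from compound 2 to compound 4 is expected, of about a number 34 percentage points higher from compound 2 to compound 4 (beyond the scatter). Compound 4 is therefore estimated to give 42%, within a range of 20% to 62%.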

Compound 4, a percentage reported as inhibition, at one concentration (the size of the read-out at that concentration, not a potency): 21%
Compound 4: the middle estimate sits 21 percentage points above what was measured; the range from low to high includes it.
By their numbers in this assay, from the lowest: compound 2; then compound 4; then compound 3; then compound 1.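

In this assay, the pyrrolidin-2-yl ring set directly on the aromatic carbon gives a number 13 percentage points higher from compound 2 to compound 4 (beyond the scatter) when it replaces 3-(dimethylamino)propyl, so at this place a ring carrying a hydrogen-bond donor still beats that chain, though only modestly. Having a pyrrolidine ring is not enough to reach the higher numbers: replacing (pyrrolidin-3-yl)methyl with pyrrolidin-2-yl gives a number 23 percentage points lower from compound 3 to compound 4 (beyond the scatter) and replacing 4-aminobutyl with it gives a number 34 percentage points lower from compound 1 to compound 4 (beyond the scatter) in the same assay, so among these four compounds the two groups with a donor-bearing nitrogen set apart from the aromatic carbon by a saturated chain stay ahead of the ring attached directly, while the group without a donor stays last. Nothing available here explains these differences.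

What the mirror-image form of the pyrrolidin-2-yl ring would give remains open, since compound 4 carries one defined stereocentre and its partner is not among the compounds shown. Also open, from the compounds shown here alone, is how a piperidine ring or an azetidine ring on the same aromatic carbon, or a primary amine on a shorter chain such as 2-aminoethyl, would compare.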